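Trading a Dithiolane Chain for a Small Amine

The source may hold more compounds than are shown below. What is called first, only, known or untested is meant among the compounds shown, and "the series" means these compounds.

Compound 1 `C=C1CC[C@H]2[C@@](C)(CC[C@@H](OC(=O)[C@H]3CCCN3)[C@@]2(C)NC=O)[C@@H]1/C=C/C1=CCOC1=O` and compound 2 `C=C1CC[C@H]2[C@@](C)(CC[C@@H](OC(=O)CCCC[C@@H]3CCSS3)[C@@]2(C)NC=O)[C@@H]1/C=C/C1=CCOC1=O` share one core and differ only in the ester group. In an assay for inhibition of hexokinase-2 (Homo sapiens), read by coupled enzyme assay, with a stated time of 10 min, in the presence of a further agent that is not named here (on this read-out higher numbers stand for weaker inhibition and lower numbers for stronger inhibition), compound 1 gives 26100 nM. In this assay compound 2 gives only a limit, > 50000 nM, which is not a number. The step of an at least 1.9-fold higher number from compound 1 to compound 2 (0.28 log units; that floor lies within the scatter) therefore rests on that limit of > 50000 nM in this assay, at which 1 of the 2 values shown sits, and says little about direction. Compound 3 `C=C1CC[C@H]2[C@@](C)(CC[C@@H](OC(=O)CNC)[C@@]2(C)NC=O)[C@@H]1/C=C/C1=CCOC1=O` follows with the change (a group of 2 heavy atoms (1 carbon, 1 nitrogen; no ring) in place of a group of 8 heavy atoms (6 carbon, 2 sulfur; one five-membered non-aromatic ring with 2 hetero atoms), on a saturated chain carbon bound to a carbonyl carbon). Going by the values given here, the group that enters is again a small nitrogen-bearing group, as in compound 1, and the one measured step between an ester with such a group and the dithiolane ester stayed at the edge of the scatter. The return is therefore expected to bring the number back near where compound 1 stands, as an at least 1.6-fold lower number from compound 2 to compound 3 (0.22 log units; that floor lies within the scatter). Compound 3 is estimated at 30000 nM, within a range from 10000 nM to 100000 nM.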

Compound 3, half-maximal inhibitory concentration: > 50000 nM
Compound 3: only a limit was reported (the forecaster's own chance of this, stated with the estimate: 35%); at least 1.6-fold (0.22 log units) between middle value and limit.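

In this assay compound 3 gives > 50000 nM, which is a limit of the assay and not a number. A small nitrogen-bearing ester group is therefore not enough on its own to give a readable number, since compound 1 remains the only one of the three esters that has one, and the comparison with its pyrrolidin-2-yl group gives an at least 1.9-fold higher number from compound 1 to compound 3 (0.28 log units; that floor lies within the scatter), which sets no firm order. The step between the dithiolane ester and the methylamino ester cannot be read because both sit at the same limit: the limit of > 50000 nM in this assay, at which 2 of the 3 values shown sit.

As far as these compounds go, it stays open how far past that limit compound 2 and compound 3 lie. From the compounds shown here alone, it also stays open whether a dimethylamino group, a piperidine ring or a carboxylic acid in this ester would give a readable number.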